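Nitro-to-amino exchange on two related dithiole cores

This account rests on a few compounds, and the source may have more. Where it says the series, first, only, none or still open, it means among the compounds named here.

Compound 1 `COc1ccc(-c2c(-c3cc(OC)c(OC)c(OC)c3)ssc2=S)cc1[N+](=O)[O-]` carries a nitro group on one aryl ring; in a functional assay on SGC-7901 cells (Homo sapiens) for antiproliferative activity, read by MTT assay, with a stated time of 72 h (a lower number here means a stronger inhibitor, a higher number a weaker inhibitor), compound 1 gives 44700 nM. Compound 2 `COc1ccc(-c2c(-c3cc(OC)c(OC)c(OC)c3)ssc2=S)cc1N` differs from compound 1 in one place: amino in place of nitro on an aromatic carbon. In this assay compound 2 gives 2620 nM, which is a 17-fold lower number from compound 1 to compound 2 (1.23 log units; beyond the scatter). Compound 3 `COc1ccc(-c2ssc(=O)c2-c2cc(OC)c(OC)c(OC)c2)cc1[N+](=O)[O-]` keeps the nitro group but sits on a different core; the difference between the core of compound 1 and the core of compound 3 is not broken down here. In this assay, within the data shown here, compound 3 gives 440 nM, the lowest of the three numbers so far, beyond the scatter from both compound 2 and compound 1. Compound 4 `COc1ccc(-c2ssc(=O)c2-c2cc(OC)c(OC)c(OC)c2)cc1N` has not yet been measured. Relative to compound 3 it shows the change (amino in place of nitro on an aromatic carbon), the same change as from compound 1 to compound 2 at a place described in the same words, so this change appears once more among the compounds shown. Among the measured compounds shown here, for compound 4 the expected step is a 7.3-fold lower number from compound 3 to compound 4 (0.87 log units; beyond the scatter), which rests on the single earlier instance of this change, a 17-fold lower number from compound 1 to compound 2 (1.23 log units; beyond the scatter), and on nothing else; with one example only, the size is uncertain and a somewhat smaller step than before is taken as the middle of the range. The estimate for compound 4 in this assay is 60 nM, within 15 nM to 250 nM.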

Compound 4, half-maximal inhibitory concentration: 172 nM
Compound 4: the middle estimate sits 2.9-fold (0.46 log units) below what was measured; low and high end bracket the measured number.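

In this assay, amino in place of nitro on an aromatic carbon again gives a lower number on the second core, a 2.6-fold lower number from compound 3 to compound 4 (0.41 log units; beyond the scatter), so the direction of the change is the same on both cores shown, but its size does not carry over from one core to the other: the same change on two cores in this assay, a 17-fold lower number (1.23 log units; beyond the scatter) from compound 1 to compound 2 and a 2.6-fold lower number (0.41 log units; beyond the scatter) from compound 3 to compound 4, 6.7-fold (0.82 log units) apart, beyond the scatter of two such steps

Two pairs show only that the direction held on these two cores; they set no rule for a further core, and the size of the step on one core would have been a poor guide to its size on another. Nothing here says why the two steps differ, and a reading of the gap in terms of the nitro group, the amino group or either core would go beyond these four compounds.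

As far as these compounds go, it remains open whether a group other than amino at the same place, such as an acetamide, a hydroxyl group or a methylamino group, would follow the amino compounds or the nitro compounds on each core. From the compounds shown here alone, it also remains open whether the exchange would go the same way on a third core, or whether the gap between the two steps would hold outside this assay.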